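Cyclopropyl to methylpyrazolyl on the shared core

The source may report more compounds than this note shows. Statements on the series, on what has been measured and on what is new or still open speak of the compounds shown alone.

Among the compounds with values here, compound 1 `Nc1ccc(S(=O)(=O)N2CCN(c3ncc(C(O)(C(F)(F)F)C(F)(F)F)cc3C3CC3)CC2)cn1` stands highest of the two numbers so far in an ADME assay (liver) for metabolic stability, with Liver microsome (Rattus norvegicus) as the target, using microsomes and NADPH, with a stated time of 30 min, tested at 1 uM (a lower number here means slower removal, a higher number faster removal of the compound), where compound 1 gives 27 mL.min-1.g-1. Its nearest neighbour compound 2 `CC(C)(O)C#Cc1cc(C(O)(C(F)(F)F)C(F)(F)F)cnc1N1CCN(S(=O)(=O)c2ccc(N)nc2)CC1` gives 16 mL.min-1.g-1 in this assay, and the step of a 1.7-fold lower number from compound 1 to compound 2 (0.23 log units; within the scatter) stays within the scatter, so the two values show no real order. Compound 3 `Cn1cc(-c2cc(C(O)(C(F)(F)F)C(F)(F)F)cnc2N2CCN(S(=O)(=O)c3ccc(N)nc3)CC2)cn1` is not yet measured. Its change from compound 1 is 1-methyl-1H-pyrazol-4-yl in place of cyclopropyl on an aromatic carbon. Within the data shown here, only the step from compound 1 to compound 2 bears on this change, since it also removes the cyclopropyl from that aromatic carbon and puts another group in its place; that step was small. Among the measured compounds shown here, no measured pair separates a five-membered aromatic ring at this place from a chain, so nothing in the data supports an expectation of a step beyond the scatter in either direction. The expected step is therefore a 1.4-fold lower number from compound 1 to compound 3 (0.13 log units; within the scatter), without a clear direction. Compound 3 is estimated at 20 mL.min-1.g-1 in this assay, within a range from 8 mL.min-1.g-1 to 50 mL.min-1.g-1.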

Compound 3, intrinsic clearance in microsomes: 44 mL.min-1.g-1
Compound 3: middle estimate off by 2.2-fold (0.34 log units), on the low side; the measured number falls inside the stated range.
By their numbers in this assay, from the lowest: compounds 2, 1 and 3 (each within the scatter of the next, the first and the last beyond it).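

The exchange at this aromatic carbon, two atoms from the ring nitrogen, now gives a step beyond the scatter in this assay: the change from 3-hydroxy-3-methylbut-1-yn-1-yl to 1-methyl-1H-pyrazol-4-yl gives a 2.8-fold higher number from compound 2 to compound 3 (0.44 log units; beyond the scatter) and is modest in size, so the read-out at this position can respond to the group placed there, which the first pair could not show. Replacing cyclopropyl, with its 3 heavy atoms and 0 hydrogen-bond acceptors, by 1-methyl-1H-pyrazol-4-yl, with 6 heavy atoms and 2 hydrogen-bond acceptors, gives a 1.6-fold higher number from compound 1 to compound 3 (0.21 log units; within the scatter) and so does not separate these two groups. No measurement bears on the reason for the separation between the chain and the five-membered aromatic ring.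

Within the data shown here, with only one group of each kind at this carbon, it remains open whether the separation belongs to five-membered aromatic rings in general or to this single pair of groups. As far as these compounds go, it also remains open how an amine such as morpholin-4-yl, a carboxylic acid or a longer chain at the same place would stand in this assay against these three compounds.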